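Solubility notes: a carbamoyl added to the pyridone core

The source may report more compounds than this note shows. Statements on the series, on what has been measured and on what is new or still open speak of the compounds shown alone.

Compound 1 `CNC(=O)c1cccn(Cc2ccccc2)c1=O` is the reference point of the series. Within the data shown here, in a physicochemical assay for solubility (a lower number here means a less soluble compound, a higher number a more soluble compound), compound 1 gives 78 ug/mL, the only plain number so far. Compound 2 `CNC(=O)c1cc(C(=O)NC2CC2)cn(Cc2cccc3c2CCN3)c1=O` gives >= 184 ug/mL in this assay, which is a limit of the assay and not a number (the limit of >= 184 ug/mL in this assay, at which 1 of the 2 values shown sits). Compound 3 `CNC(=O)c1cc(C(=O)NC2CCC2)cn(Cc2ccccc2)c1=O` is not yet measured. It differs from compound 1 in one place: cyclobutylcarbamoyl in place of hydrogen on an aromatic carbon.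

Among the measured compounds shown here, no step between measured compounds exists to size this change. For the measured compounds named here, the only other compound carrying a carbamoyl on the core, compound 2, sits at its limit, but it also differs elsewhere, so it sets no direction. The step of a 1.1-fold higher number from compound 1 to compound 3 (0.04 log units; within the scatter) is expected to stay within the usual scatter, with a small move in either direction possible. Compound 3 is estimated at 85 ug/mL, between 30 ug/mL and 240 ug/mL.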

Compound 3, solubility: 28 ug/mL
For compound 3 the middle estimate is 3.0-fold (0.48 log units) above the measured one, and the stated range ends above it.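

this assay now has a sized step at this position: with cyclobutylcarbamoyl in place of hydrogen on an aromatic carbon, two atoms from the ring nitrogen, the series shows a 2.8-fold lower number from compound 1 to compound 3 (0.44 log units; beyond the scatter). Among these compounds, on the core of compound 1 this change therefore has a direction, downward and beyond the scatter, which no earlier pair could give. Compound 2 also carries a carbamoyl on the core but differs elsewhere too, and its value is a limit of the assay and not a number: the limit of >= 184 ug/mL in this assay, at which 1 of the 3 values shown sits.

One step at one position cannot separate the part played by the cyclobutyl ring from that of the carbamoyl link. Going by these compounds, whether a carboxylic acid or a primary amine on a short chain at this position would point the same way remains open, as does whether the step keeps its size without the benzyl group.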